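Changing the hydrazone aryl group on a shared triazolopyrimidine-like core

The source may hold more compounds than are shown below. What is called first, only, known or untested is meant among the compounds shown, and "the series" means these compounds.

Three compounds share one core and differ only in the aryl group carried on the hydrazone. Compound 1 `CCCSc1nc(N/N=C(\C)c2ccc(OC)cc2)c2nnn(Cc3ccccc3)c2n1` was tested in a functional assay on ECa-109 cells (Homo sapiens) for antiproliferative activity, read by MTT assay, with a stated time of 72 h; a higher number here means a weaker inhibitor, a lower number a stronger inhibitor; for compound 1 the result is only a limit, > 64000 nM. Compound 2 `CCCSc1nc(N/N=C/c2ccccc2F)c2nnn(Cc3ccccc3)c2n1` likewise gives only a limit in this assay, > 64000 nM. Compound 3 `CCCSc1nc(N/N=C/c2cc(OC)c(OC)c(OC)c2)c2nnn(Cc3ccccc3)c2n1` gives 4060 nM in this assay, a number rather than a limit, so compound 3 is the only one of the three with a measured value. Compound 2 therefore stands at the limit of > 64000 nM in this assay, at which 2 of the 3 values shown sit, and it offers no number of its own that could be set against compound 3.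

The step to compound 4 `CCCSc1nc(N/N=C/c2ccc(N(C)C)cc2)c2nnn(Cc3ccccc3)c2n1` swaps the aryl group: 4-(dimethylamino)phenyl in place of 2-fluorophenyl on a carbon with a double bond to nitrogen. Among the compounds with values here, no measured pair carries this change. Within the data shown here, compound 1 and compound 2 show only that two different aryl groups both sit at the limit, while compound 3 shows that a third aryl group yields a measurable value. In this assay the expected step is an at least 3.2-fold lower number from compound 2 to compound 4 (0.50 log units; beyond the scatter), downward by an uncertain amount. Compound 4 is expected to give about 20000 nM in this assay, within 4000 nM to 64000 nM, with a real chance that only a limit is reported once more.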

Compound 4, half-maximal inhibitory concentration: 20000 nM
Estimate against measurement, compound 4: no gap at the digits printed; the range from low to high includes it.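

In this assay, within the data shown here, the swap of 2-fluorophenyl for 4-(dimethylamino)phenyl on a carbon with a double bond to nitrogen gives an at least 3.2-fold lower number from compound 2 to compound 4 (0.50 log units; beyond the scatter) and so provides the first step that can be read at this position. Compound 4 is a second compound, after compound 3, whose aryl group gives a number rather than a limit, so a measured value here does not depend on the aryl group of compound 3 alone. On these data alone, the full size of the step remains unknown because compound 2 has no number of its own, which makes the printed step a floor only: the limit of > 64000 nM in this assay, at which 2 of the 4 values shown sit.

The compounds shown leave open whether the change in compound 4 comes from adding the dimethylamino group or from removing the fluorine, a question that a plain phenyl on this carbon would help to separate. As far as these compounds go, it is also open whether a free amine or a morpholine in place of the dimethylamino group would keep, lower or raise the number seen for compound 4.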